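The source may report more compounds than this note shows. Statements on the series, on what has been measured and on what is new or still open speak of the compounds shown alone.

Working notes on the series. The shared core of compound 1 `COc1ccc(-c2nnc(-n3[se]c4ccccc4c3=O)s2)cc1` carries an aryl group on the five-membered ring; in a functional assay on A549 cells (Homo sapiens) for antiproliferative activity, read by CCK-8 assay, with a stated time of 48 h (on this read-out lower numbers stand for stronger inhibition and higher numbers for weaker inhibition), compound 1 gives 5930 nM. Compound 2 `O=c1c2ccccc2[se]n1-c1nnc(-c2ccc(F)cc2)s1` gives 21100 nM, and compound 3 `O=c1c2ccccc2[se]n1-c1nnc(-c2cc([N+](=O)[O-])cc([N+](=O)[O-])c2)s1` gives 17900 nM. Going by the values given here, compound 2 holds the highest number of the three: its gap to compound 3 lies within the scatter, so the two are not told apart, while the step of a 3.6-fold higher number from compound 1 to compound 2 (0.55 log units; beyond the scatter) lies beyond the scatter and is the one measured change on this aryl ring.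

The next step goes from compound 2 to compound 4 `O=c1c2ccccc2[se]n1-c1nnc(-c2ccccc2Br)s1`: 2-bromophenyl in place of 4-fluorophenyl on an aromatic carbon. Among the compounds with values here, only the step from compound 1 to compound 2 bears on a change at this position, and it was modest; no measured pair exchanges one halogen for another or moves a substituent around the ring, and compound 3 shows merely that a heavily substituted ring lands within the scatter of compound 2. The expectation is therefore a step no larger than the scatter in this assay, with no clear direction, giving an estimated 1.3-fold lower number from compound 2 to compound 4 (0.12 log units; within the scatter). Compound 4 is expected near 16000 nM, within 5000 nM to 50000 nM, the wide range reflecting that nothing measured here tests a bromine or a change of ring position directly.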

Compound 4, half-maximal inhibitory concentration: 12700 nM
Beside the measured number, compound 4's estimate is 1.3-fold (0.10 log units) above it, within the range that was stated.
By their numbers in this assay, from the lowest: compound 1; then compounds 4, 3 and 2 (each within the scatter of the next).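

In this assay, the step of a 1.7-fold lower number from compound 2 to compound 4 (0.22 log units; within the scatter) lies within the scatter, so the two are not told apart, although 2-bromophenyl differs from 4-fluorophenyl in both the halogen and where it sits on the phenyl ring. The earlier step of a 3.6-fold higher number from compound 1 to compound 2 (0.55 log units; beyond the scatter) lies beyond the scatter, so the new result shows that, at this aromatic carbon of the five-membered ring, one exchange of aryl group separates two compounds and another does not. No supporting measurement is available to explain this result.

Because the halogen and its place change together here, the two changes cannot be read apart, and a matched 2-fluorophenyl or 4-bromophenyl group would be needed to separate them. From the compounds shown here alone, it also remains open whether an aminophenyl group, a carboxyphenyl group or a simple n-butyl chain at this position would give a step beyond the scatter from compound 2, and in which direction.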